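A few compounds are considered here, and "the series" means these few. Any claim that something is new, unique, unknown or untested is made for them only; others in the source may bear on it.

For the measured compounds named here, compound 2 `COc1ccc(Cn2cc(/C=N\NC(=O)c3c[nH]c4ccc(Br)cc34)c3cc(OC)ccc32)cc1` gives 61200 nM in a functional assay on MDA-MB-231 cells (Homo sapiens) for cytotoxicity (on this read-out higher numbers stand for weaker inhibition and lower numbers for stronger inhibition), the highest of the two numbers so far. Its nearest neighbour is compound 1 `COc1ccc(Cn2cc(/C=N\NC(=O)c3c[nH]c4ccccc34)c3cc(OC)ccc32)cc1` with 9800 nM; the step of a 6.2-fold higher number from compound 1 to compound 2 (0.80 log units; beyond the scatter) is the only measured one and concerns a different place. Compound 3 `COc1ccc2c(c1)c(/C=N\NC(=O)c1c[nH]c3ccc(Br)cc13)cn2Cc1ccc(Cl)cc1` differs from compound 2 by chloro in place of methoxy on an aromatic carbon. Going by the values given here, no measured step bears on this exchange, so no step beyond the scatter is assumed. For compound 3 the expected value in this assay is 61200 nM, with a range of 20000 nM to 180000 nM, which means an estimated step of no change at the digits printed from compound 2 to compound 3 (within the scatter).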

Compound 3, half-maximal inhibitory concentration: 5000 nM
For compound 3 the middle estimate is 12-fold (1.09 log units) above the measured one, outside the stated range (below it).
By their numbers in this assay, from the lowest: compounds 3 and 1 (each within the scatter of the next); then compound 2.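

In this assay, chloro in place of methoxy at the 4-position of the benzyl group gives a 12-fold lower number from compound 2 to compound 3 (1.09 log units; beyond the scatter). For the compounds shown here, this is the first measured change at this position, so the position is not silent: with the bromo group held constant, the exchange shifts the read-out towards stronger inhibition. Nothing on hand explains the size or direction of this step. From the compounds shown here alone, whether the exchange gives a similar step without the bromo group, starting from compound 1, remains open. So does how this position responds to other groups, such as an amine or a carboxylic acid.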